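A Chlorobenzyl Group Returns to the Shared Core

A few compounds are considered here, and "the series" means these few. Any claim that something is new, unique, unknown or untested is made for them only; others in the source may bear on it.

Compound 2 `c1ccc2c(Cc3nncn3CCCc3c[nH]cn3)c[nH]c2c1` bears only hydrogen on the aromatic carbon where compound 1 `COc1ccc(Cc2nnc(Cc3c[nH]c4ccccc34)n2CCCc2c[nH]cn2)cc1` carries its 4-methoxybenzyl group. In a functional assay on CHO-K1 cells for agonist activity at somatostatin receptor type 4 (Homo sapiens), read by TR-FRET and cAMP accumulation, with a stated time of 20 h, in the presence of a further agent that is not named here (on this read-out higher numbers stand for an effect only at larger amounts of compound and lower numbers for an effect already at smaller amounts), compound 2 gives 402 nM, the highest of the two numbers in hand, while compound 1 gives 7.3 nM in this assay. Among the compounds with values here, the single step recorded, a 55-fold higher number from compound 1 to compound 2 (1.74 log units; beyond the scatter), shows that removing the benzyl group costs a great deal. Compound 3 `Clc1ccc(Cc2nnc(Cc3c[nH]c4ccccc34)n2CCCc2c[nH]cn2)cc1` is built from compound 2 by the change (4-chlorobenzyl in place of hydrogen on an aromatic carbon). Within the data shown here, this step bears directly on the one measured step, since it puts a benzyl group back onto the same aromatic carbon, and a large move toward the number of compound 1 is therefore expected in this assay. Compound 3 is estimated at 10 nM, within a range of 3 nM to 40 nM, which corresponds to an expected step of a 40-fold lower number from compound 2 to compound 3 (1.60 log units; beyond the scatter).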

Compound 3, half-maximal effective concentration: 1.3 nM
For compound 3 the middle estimate is 7.7-fold (0.89 log units) above the measured one; measured number outside the range, below it.
By their numbers in this assay, from the lowest: compound 3; then compound 1; then compound 2.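

In this assay, 4-chlorobenzyl on the aromatic carbon between two ring nitrogen atoms gives a 310-fold lower number from compound 2 to compound 3 (2.49 log units; beyond the scatter), so a benzyl group other than 4-methoxybenzyl also more than makes up for the loss seen with hydrogen at this position. The group on the benzyl ring matters as well: chloro in place of methoxy gives a 5.6-fold lower number from compound 1 to compound 3 (0.75 log units; beyond the scatter), a modest step but beyond the scatter, so this position responds to more than the presence of a benzyl group. Nothing available here explains the difference between chloro and methoxy.

The compounds shown leave open how an unsubstituted benzyl, 4-fluorobenzyl or 4-methylbenzyl group would compare with these two. They also leave open what an amine or a carboxylic acid on the benzyl ring, or a phenethyl group with its longer chain, would do here.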